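Quinazolinyl thiosemicarbazides: moving the chlorine around the phenyl ring

The source may report more compounds than this note shows. Statements on the series, on what has been measured and on what is new or still open speak of the compounds shown alone.

Three compounds share a core carrying an aroyl group. Compound 1 `O=C(NC(=S)NNc1ncnc2ccccc12)c1ccc(C(F)(F)F)cc1` gives 12200 nM in a functional assay on GLC82 cells (Homo sapiens) for cytotoxicity, read by MTT assay, with a stated time of 72 h; a lower number here means a stronger inhibitor, a higher number a weaker inhibitor; compound 2 `O=C(NC(=S)NNc1ncnc2ccccc12)c1cccc(Cl)c1` gives 3240 nM there, and compound 3 `COc1ccccc1C(=O)NC(=S)NNc1ncnc2ccccc12` gives 9500 nM. Compound 3 thus stands second highest of the three numbers, close to compound 1 and further from compound 2. Compound 4 `O=C(NC(=S)NNc1ncnc2ccccc12)c1ccc(Cl)cc1` is obtained from compound 3 by the change (4-chlorophenyl in place of 2-methoxyphenyl on a carbonyl carbon). For the measured compounds named here, the one step that bears on it is the exchange of a chlorophenyl for the methoxyphenyl, a 2.9-fold higher number from compound 2 to compound 3 (0.47 log units; beyond the scatter), a modest rise. Reversing that kind of change, compound 4 is expected to give a lower number than compound 3, by a 2.1-fold lower number from compound 3 to compound 4 (0.32 log units; beyond the scatter), though compound 1 warns that a 4-substituted ring gave the highest number. The estimate for compound 4 is 4500 nM, within 1800 nM to 11000 nM.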

Compound 4, half-maximal inhibitory concentration: 6680 nM
The estimate for compound 4 lay 1.5-fold (0.17 log units) below the measured number; low and high end bracket the measured number.
By their numbers in this assay, from the lowest: compound 2; then compounds 4, 3 and 1 (each within the scatter of the next).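

In this assay the place of the chlorine on the ring counts, since 4-chlorophenyl in place of 3-chlorophenyl gives a 2.1-fold higher number from compound 2 to compound 4 (0.31 log units; beyond the scatter) and stays a modest step. Exchanging 2-methoxyphenyl for 4-chlorophenyl gives a 1.4-fold lower number from compound 3 to compound 4 (0.15 log units; within the scatter) and chloro in place of trifluoromethyl on an aromatic carbon gives a 1.8-fold lower number from compound 1 to compound 4 (0.26 log units; within the scatter) so neither change separates its pair. Nothing available accounts for these steps. Still open, from the compounds shown here alone, is how an aminophenyl or a carboxyphenyl on the same carbonyl carbon would compare with the 3-chlorophenyl of compound 2.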